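Carboxy in place of hydroxy on compound 1

This account rests on a few compounds, and the source may have more. Where it says the series, first, only, none or still open, it means among the compounds named here.

In a functional assay on A-375 cells (Homo sapiens) for antiproliferative activity, read by MTT assay, with a stated time of 24 h (a higher number here means a weaker inhibitor, a lower number a stronger inhibitor), compound 1 `Cc1ccc2nc(C(=O)Nc3c(F)cc(-c4cccc(F)c4)cc3F)c(C)c(O)c2c1` gives 90500 nM and compound 3 `Cc1c(C(=O)Nc2c(F)cc(-c3cccc(F)c3)cc2F)nc2ccc(F)cc2c1O` gives 65300 nM, with a 1.4-fold lower number from compound 1 to compound 3 (0.14 log units; within the scatter). Compound 2 `CCc1ccc2nc(C(=O)Nc3c(F)cc(-c4cccc(F)c4)cc3F)c(C)c(O)c2c1` gives 8130 nM, with an 11-fold lower number from compound 1 to compound 2 (1.05 log units; beyond the scatter) and an 8.0-fold higher number from compound 2 to compound 3 (0.90 log units; beyond the scatter). Compound 1 thus stands at the high end of these numbers. Compound 4 `Cc1ccc2nc(C(=O)Nc3c(F)cc(-c4cccc(F)c4)cc3F)c(C)c(C(=O)O)c2c1` carries carboxy in place of hydroxy on an aromatic carbon, opposite the ring nitrogen: carboxy in place of hydroxy on an aromatic carbon. For the measured compounds named here, no measured step touches this place. Going by the values given here, the measured steps show only that a single change can move the number, as in an 11-fold lower number from compound 1 to compound 2 (1.05 log units; beyond the scatter), or leave it within the scatter, as in a 1.4-fold lower number from compound 1 to compound 3 (0.14 log units; within the scatter). The expected step is a modest drop, estimated as a 4.5-fold lower number from compound 1 to compound 4 (0.66 log units; beyond the scatter), though with little support. For compound 4 the estimated value is 20000 nM, within an expected range of 3000 nM to 90000 nM.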

Compound 4, half-maximal inhibitory concentration: 26000 nM
For compound 4 the middle estimate is 1.3-fold (0.11 log units) below the measured one; the measured number falls inside the stated range.
By their numbers in this assay, from the lowest: compound 2; then compound 4; then compounds 3 and 1 (each within the scatter of the next).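

In this assay, for the compounds shown here, the place opposite the ring nitrogen, which no earlier step touched, proves to affect the number: carboxy in place of hydroxy gives a 3.5-fold lower number from compound 1 to compound 4 (0.54 log units; beyond the scatter). Hydroxy is therefore not required here for the activity of compound 1, since a larger group with more heavy atoms is tolerated on this aromatic carbon. No measurement offered here accounts for this step.

From the compounds shown here alone, whether an amine or a methoxy group at this place would give a similar number remains open. So does whether carboxy here combines with the ethyl group of compound 2.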